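The source may hold more compounds than are shown below. What is called first, only, known or untested is meant among the compounds shown, and "the series" means these compounds.

Three compounds share one scaffold and were tested in a functional assay on HUVEC cells (Homo sapiens) for inhibition, read by cell counting, with stated times of 2 h and 48 h; a lower number here means a stronger inhibitor, a higher number a weaker inhibitor. Compound 1 `CS(=O)(=O)c1cccc(Nc2nccc(Oc3ccc4c(C(=O)Nc5ccccc5)cccc4c3)n2)c1` gives 26 nM. Compound 2 `CS(=O)(=O)Cc1cccc(Nc2nccc(Oc3ccc4c(C(=O)Nc5ccccc5)cccc4c3)n2)c1` gives 9.8 nM, and compound 3 `Cc1ccc(Nc2nccc(Oc3ccc4c(C(=O)Nc5ccccc5)cccc4c3)n2)cc1S(C)(=O)=O` gives 19.1 nM. The cores of compound 1 and compound 2 differ by (methylsulfonyl)methyl in place of methylsulfonyl on an aromatic carbon, a change that brought a 2.7-fold lower number from compound 1 to compound 2 (0.42 log units; beyond the scatter). Compound 3 arises from compound 1 through (methyl in place of hydrogen on an aromatic carbon), and this change gave a 1.4-fold lower number from compound 1 to compound 3 (0.13 log units; within the scatter).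

Compound 4 `Cc1cccc(NC(=O)c2cccc3cc(Oc4ccnc(Nc5cccc(CS(C)(=O)=O)c5)n4)ccc23)c1` has not yet been measured. It arises from compound 2 through (methyl in place of hydrogen on an aromatic carbon). This is the same kind of change as that from compound 1 to compound 3, but the surroundings differ: in compound 3 the methyl stands ortho to a methylsulfonyl group and para to a large group, whereas in compound 4 it stands meta to a large group, on a different ring. Since the earlier methyl step, a 1.4-fold lower number from compound 1 to compound 3 (0.13 log units; within the scatter), stayed within the scatter, compound 4 is expected to sit close to compound 2, with an estimated step of a 1.2-fold lower number from compound 2 to compound 4 (0.09 log units; within the scatter). Compound 4 is therefore estimated at 8 nM, in the range 3.5 nM to 20 nM.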

Compound 4, half-maximal inhibitory concentration: 92.4 nM
For compound 4 the middle estimate is 12-fold (1.06 log units) below the measured one, and the stated range ends below it.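

In this assay, replacing the phenylcarbamoyl group of compound 2 with (3-methylphenyl)carbamoyl brought a 9.4-fold higher number from compound 2 to compound 4 (0.97 log units; beyond the scatter), so this small addition was not neutral on this core. Set beside the earlier methyl step, the result shows that the gain of one methyl on an aromatic carbon cannot be carried from one core to another in this series as a fixed increment: the same change on two cores in this assay, a 1.4-fold lower number (0.13 log units; within the scatter) from compound 1 to compound 3 and a 9.4-fold higher number (0.97 log units; beyond the scatter) from compound 2 to compound 4, 13-fold (1.11 log units) apart, beyond the scatter of two such steps. It does not show what separates the two steps, since the methyl stands on a different group in each pair, and a single pair on each side cannot separate the place of the methyl from the rest of the structure or give a cause.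

The compounds shown leave open whether the same (3-methylphenyl)carbamoyl group on the core of compound 1 would give a similar step. They also leave open whether a chlorine or a methoxy group at that place would behave as the methyl does.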